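Swapping the Aryl Group on a Shared Core

A few compounds are considered here, and "the series" means these few. Any claim that something is new, unique, unknown or untested is made for them only; others in the source may bear on it.

Compound 3 `CC(C)OC(=O)N1CCC(Oc2ncnc3c2CCN3c2ccc(S(C)(=O)=O)cn2)CC1` stands second highest of the three numbers in a functional assay on CHO-K1 cells with Glucose-dependent insulinotropic receptor (Homo sapiens) as the target, read by a luciferase reporter, with a stated time of 5 h (a higher number here means a larger maximal response, a lower number a smaller maximal response), where compound 3 gives 111%. Going by the values given here, compound 1 `CCOC(=O)N1CCC(Oc2ncnc3c2CCN3c2ccc(S(C)(=O)=O)cc2F)CC1` gives 135% and compound 2 `CC(C)S(=O)(=O)N1CCC(Oc2ncnc3c2CCN3c2ccc(S(C)(=O)=O)cc2F)CC1` gives 62%; the only single-site step measured, a number 73 percentage points lower from compound 1 to compound 2 (beyond the scatter), concerns the amine nitrogen in a ring and not the part changed here. Compound 4 `CC(C)OC(=O)N1CCC(Oc2ncnc3c2CCN3c2ccc([S@+](C)[O-])c(F)c2)CC1` differs from compound 3 by a group of 10 heavy atoms (7 carbon, 1 oxygen, 1 fluorine, 1 sulfur; one six-membered aromatic ring of carbon only) in place of a group of 10 heavy atoms (6 carbon, 1 nitrogen, 2 oxygen, 1 sulfur; one six-membered aromatic ring with 1 hetero atom), on a nitrogen on an aromatic ring in a ring. Among the compounds with values here, no measured step touches this place, so the measured steps offer no direct guide, and no shift beyond the scatter is expected in either direction. Compound 4 is therefore expected to give about 110%, with a likely range from 70% to 150%, meaning an expected step of a number 1 percentage points lower from compound 3 to compound 4 (within the scatter).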

Compound 4, largest response reached (reported as percent of maximum), in percent of the reference or control that the assay uses: 122%
The estimate for compound 4 lay 12 percentage points below the measured number; low and high end bracket the measured number.
By their numbers in this assay, from the lowest: compound 2; then compound 3; then compound 4; then compound 1.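

This place, on a nitrogen on an aromatic ring in a ring, tolerates a full exchange of the aryl group: this assay shows a number 11 percentage points higher from compound 3 to compound 4 (beyond the scatter). The step is modest, and the response stays high with a ring of carbon only in place of the 5-(methylsulfonyl)pyridin-2-yl group. The entering group differs in its ring atoms, its fluorine and its defined stereocentre all at once, and nothing available explains the rise. Which of these differences matters remains open. A plain phenyl, or a pyridine carrying an amine, could help separate them.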